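Methoxy in place of hydrogen on the fused ring of compound 1

This account rests on a few compounds, and the source may have more. Where it says the series, first, only, none or still open, it means among the compounds named here.

Compound 1 `CCOC(=O)c1c(-c2cc3ccccc3oc2=O)nn(-c2ccccc2)c1C(=O)OCC` holds the highest number of the three measured in a functional assay on A549 cells (Homo sapiens) for cytotoxicity, read by MTT assay, with a stated time of 48 h; on this read-out higher numbers stand for weaker inhibition and lower numbers for stronger inhibition: compound 1 gives 100000 nM. Compound 2 `CCOC(=O)c1c(-c2cc3ccccc3oc2=O)nn(-c2cccc(C)c2)c1C(=O)OCC` gives 52000 nM, and compound 3 `CCOC(=O)c1c(-c2cc3ccccc3oc2=O)nn(-c2cccc(Cl)c2)c1C(=O)OCC` gives 28000 nM. The two measured steps from compound 1 both lower the number: a 1.9-fold lower number from compound 1 to compound 2 (0.28 log units; within the scatter) and a 3.6-fold lower number from compound 1 to compound 3 (0.55 log units; beyond the scatter); the third, a 1.9-fold lower number from compound 2 to compound 3 (0.27 log units; within the scatter), is within the scatter.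

Compound 4 `CCOC(=O)c1c(-c2cc3cc(OC)ccc3oc2=O)nn(-c2ccccc2)c1C(=O)OCC` differs from compound 1 by methoxy in place of hydrogen on an aromatic carbon. All three measured steps change a substituent on the phenyl attached to nitrogen; none touches the fused ring system, so none bears directly on this change. Going by the values given here, the observed steps show that a small substituent elsewhere can lower the number modestly, but no step shows the effect at this new place. The expected step in this assay is therefore none beyond the scatter, a 1.3-fold lower number from compound 1 to compound 4 (0.10 log units; within the scatter), leaning slightly lower. Compound 4 is estimated at 80000 nM, with a range from 30000 nM to 200000 nM.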

Compound 4, half-maximal inhibitory concentration: 35000 nM
Compound 4: middle estimate off by 2.3-fold (0.36 log units), on the high side; the range from low to high includes it.
By their numbers in this assay, from the lowest: compounds 3, 4, 2 and 1 (each within the scatter of the next, the first and the last beyond it).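

In this assay, methoxy in place of hydrogen on the fused ring gives a 2.9-fold lower number from compound 1 to compound 4 (0.46 log units; beyond the scatter), the only step shown at this place and one that lies beyond the scatter. Going by these compounds alone, the number of compound 1 therefore responds to a change on the fused ring, whereas the earlier steps, a 1.9-fold lower number from compound 1 to compound 2 (0.28 log units; within the scatter) and a 3.6-fold lower number from compound 1 to compound 3 (0.55 log units; beyond the scatter), showed only changes on the other aromatic ring. No measurement on hand accounts for the step at this place.

From the compounds shown here alone, whether the step is specific to methoxy remains open, as hydroxy, an amine or a longer chain such as butoxy at the same place would be needed to test that. Also open, going by these compounds, is whether methoxy on the fused ring and chloro as in compound 3 would together lower the number further than either change alone.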